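Shifting the benzyl substituent on a pyrazolyl xanthine

This account rests on a few compounds, and the source may have more. Where it says the series, first, only, none or still open, it means among the compounds named here.

Compound 1 `CCCCn1c(=O)c2nc(-c3cnn(Cc4ccccc4)c3)[nH]c2n(CCCC)c1=O`: 1400 nM
Compound 2 `CCCn1c(=O)c2nc(-c3cnn(Cc4ccc(F)cc4F)c3)[nH]c2n(CCC)c1=O`: "not determined" (no result reported)
Compound 3 `CCCn1c(=O)c2nc(-c3cnn(Cc4ccc(OC)c(C(F)(F)F)c4)c3)[nH]c2n(CCC)c1=O`: "not determined" (no result reported)

The three measured compounds share the same core and differ in the chain on the core nitrogens and in the group on the benzyl ring. In an assay on CHO cells for displacement of a labelled ligand from adenosine receptor A1 (Homo sapiens) (a higher number here means a weaker inhibitor, a lower number a stronger inhibitor), compound 1 gives 1400 nM. For compound 2, which carries 2,4-difluorophenyl on the saturated chain carbon bound to the aromatic nitrogen, no single number was reported in this assay, and compound 3 is a further entry without a single number. Within the data shown here, compound 2 therefore stands without a value of its own, and the only number in the set belongs to compound 1.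

Compound 4 `CCCn1c(=O)c2nc(-c3cnn(Cc4ccccc4OC)c3)[nH]c2n(CCC)c1=O` is the unmeasured compound. It differs from compound 2 in one place: 2-methoxyphenyl in place of 2,4-difluorophenyl on a saturated chain carbon bound to an aromatic nitrogen. Among the measured compounds shown here, with no measured step between compounds of this kind, no size or direction can be read from the data; any step from compound 2 to compound 4 in this assay is expected to be modest, and could lie within the scatter. Compound 4 is estimated to give 800 nM in this assay, with a range from 200 nM to 4000 nM.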

Compound 4, inhibition constant: 59 nM
The estimate for compound 4 lay 14-fold (1.13 log units) above the measured number; measured number below the stated range.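

Among these compounds, compound 4 gives 59 nM in this assay, but compound 2 has no single number there, and no step from compound 2 to compound 4 can be read. The compounds shown leave open how much of that value goes with the 2-methoxybenzyl group. No data shown here bear on a cause for this value.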